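This account rests on a few compounds, and the source may have more. Where it says the series, first, only, none or still open, it means among the compounds named here.

Compound 1, `Cc1cc(NC(=O)Nc2cc(F)ccc2F)c2ccccc2n1`: in an ADME assay on HepG2 cells (Homo sapiens) for cytotoxicity, with a stated time of 72 h (on this read-out higher numbers stand for an effect only at larger amounts of compound and lower numbers for an effect already at smaller amounts), compound 1 gives > 25000 nM, which is a limit of the assay and not a number.
Compound 2, `Cc1cc(NC(=O)Nc2ccccc2C(N)=O)c2ccccc2n1`: in this assay compound 2 gives > 25000 nM, again a limit.
Compound 3, `Cc1cc(NC(=O)Nc2ccccc2[N+](=O)[O-])c2ccccc2n1`: in this assay compound 3 gives > 25000 nM, also a limit.

For the measured compounds named here, compound 3 therefore stands where every value so far stands, at the limit of > 25000 nM in this assay, at which 3 of the 3 values shown sit. Going by the values given here, only one step between measured compounds is available, and it runs from compound 2 to compound 3: a step that the two limits leave unreadable from compound 2 to compound 3. Both ends of that step are limits, so it gives no readable size and no direction.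

The next compound is compound 4, `COc1ccccc1NC(=O)Nc1cc(C)nc2ccccc12`. It differs from compound 3 by methoxy in place of nitro on an aromatic carbon.

Among the compounds with values here, no measured step in this set speaks to methoxy in place of nitro, and the single step that exists, from a carbamoyl to a nitro group, is unreadable. The three measured compounds all sit at the same limit, so compound 3 gives no foothold for expecting a move in either direction. The expectation for compound 4 is thus no step beyond the scatter: an estimated step that the limit leaves unreadable from compound 3 to compound 4 in this assay. Compound 4 is accordingly expected to come out at about 40000 nM, with a likely range from 20000 nM to 120000 nM, most probably reported again as a limit.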

Compound 4, half-maximal effective concentration: > 25000 nM
Compound 4 was reported as a limit; the forecaster's own chance of this, stated with the estimate: 75%; the middle value lies beyond the limit too.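

In this assay compound 4 gives > 25000 nM, again a limit and not a number, so its steps from compound 2 and compound 3 cannot be read. All the compounds shown sit at one value: the limit of > 25000 nM in this assay, at which 4 of the 4 values shown sit.

They leave open how methoxy, nitro and carbamoyl compare in this assay, and at what concentration any of these compounds has an effect.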